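From an open amine chain to a ring

A few compounds are considered here, and "the series" means these few. Any claim that something is new, unique, unknown or untested is made for them only; others in the source may bear on it.

- compound 1 `c1cc([C@H]2CC[C@]3(CC2)OOC2(O3)C3CC4CC(C3)CC2C4)ccc1OCCOC1CCNCC1` gives 9180 ng.h/mL in an ADME assay on the whole organism (strain FVB) for pharmacokinetics, with Mus musculus as the target, read by LC-MS, at a dose of 30 mg/kg by the oral route; on this read-out lower numbers stand for lower exposure and higher numbers for higher exposure at the dose given
- compound 2 `CC(C)(O)CNCCCOc1ccc([C@H]2CC[C@]3(CC2)OOC2(O3)C3CC4CC(C3)CC2C4)cc1` gives 11100 ng.h/mL
- compound 3 `NCCCCOc1ccc([C@H]2CC[C@]3(CC2)OOC2(O3)C3CC4CC(C3)CC2C4)cc1` gives 4700 ng.h/mL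

Two steps show where compound 3 stands among these numbers (a 2.4-fold lower number from compound 2 to compound 3 (0.37 log units; beyond the scatter)) and (a 2.0-fold lower number from compound 1 to compound 3 (0.29 log units; within the scatter)). Compound 4 `CC1(C)CC(O)(COc2ccc([C@H]3CC[C@]4(CC3)OOC3(O4)C4CC5CC(C4)CC3C5)cc2)CC(C)(C)N1` keeps the shared core but changes the side chain (4-hydroxy-2,2,6,6-tetramethylpiperidin-4-yl in place of 3-aminopropyl on a saturated chain carbon bound to an oxygen on an aromatic ring), with 4-hydroxy-2,2,6,6-tetramethylpiperidin-4-yl in place of 3-aminopropyl on a saturated chain carbon bound to an oxygen on an aromatic ring. For the measured compounds named here, no measured step makes this exact change. The closest guides are those same two modest steps, and the side chain of compound 1 also holds a ring (a 2.0-fold lower number from compound 1 to compound 3 (0.29 log units; within the scatter)). In this assay the expected step is small and upward (a 1.6-fold higher number from compound 3 to compound 4 (0.20 log units; within the scatter)). For compound 4 the estimated value is 7500 ng.h/mL (expected range 2800 ng.h/mL to 20000 ng.h/mL).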

Compound 4, area under the concentration-time curve: 17300 ng.h/mL
Estimate against measurement, compound 4: 2.3-fold (0.36 log units) below, within the range that was stated.
By their numbers in this assay, from the lowest: compounds 3, 1, 2 and 4 (each within the scatter of the next, the first and the last beyond it).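

In this assay, a ring carried directly on this chain carbon can stand in place of the open chain: 4-hydroxy-2,2,6,6-tetramethylpiperidin-4-yl in place of 3-aminopropyl gives a modest rise (a 3.7-fold higher number from compound 3 to compound 4 (0.57 log units; beyond the scatter)). Against the other two side chains, the steps stay within the scatter (a 1.6-fold higher number from compound 2 to compound 4 (0.19 log units; within the scatter)) and (a 1.9-fold higher number from compound 1 to compound 4 (0.28 log units; within the scatter)). Nothing available explains the rise.

From the compounds shown here alone, compound 4 brings in the ring, its hydroxyl and its methyl groups all at once, so their separate shares remain unknown. A plain piperidin-4-yl group, without the hydroxyl or the methyl groups, would help to separate them.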